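A few compounds are considered here, and "the series" means these few. Any claim that something is new, unique, unknown or untested is made for them only; others in the source may bear on it.

Measured compounds:

compound 1, `CCCN(C(=O)CN(C)C(=O)c1ccc(S(C)(=O)=O)c([N+](=O)[O-])c1)c1ccccc1` — > 60000 nM
compound 2, `CC1CCN(C(=O)CCCNC(=O)c2ccc(S(C)(=O)=O)c([N+](=O)[O-])c2)CC1` — > 60000 nM

Both measurements come from an assay on isolated protein for inhibition of vitamin D3 receptor (Homo sapiens), read by fluorescence polarization; on this read-out higher numbers stand for weaker inhibition and lower numbers for stronger inhibition. In this assay compound 1 gives only a limit, > 60000 nM, which means the assay reports no number for it, only the edge of what it can measure. Compound 2 gives the same kind of limit, > 60000 nM, in this assay. So compound 1 stands nowhere in particular among the numbers shown: there are no numbers, only (the limit of > 60000 nM in this assay, at which 2 of the 2 values shown sit).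

Compound 3, `CC1CCN(C(=O)CN(C)C(=O)c2ccc(S(C)(=O)=O)c([N+](=O)[O-])c2)CC1`, has not yet been measured in this assay. It differs from compound 1 in one place: 4-methylpiperidin-1-yl in place of phenyl(propyl)amino on a carbonyl carbon. The new group is the same ring amide that compound 2 carries, while the rest of compound 3 stays as in compound 1.

Among the measured compounds shown here, with both measured compounds sitting at the limit, no step between measured compounds can be drawn, and nothing suggests a change beyond the usual scatter. Compound 3 is therefore expected to sit at the limit too. The estimated step that the limit leaves unreadable from compound 1 to compound 3 is expected to be essentially none. For compound 3 the estimated value in this assay is 100000 nM, expected to lie between 30000 nM and 300000 nM.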

Compound 3, half-maximal inhibitory concentration: > 60000 nM
Compound 3 gave a limit, no number; the forecaster's own chance of this, stated with the estimate: 85%; the middle value does not contradict the limit.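

In this assay compound 3 gives > 60000 nM, which is a limit and not a number. Among the compounds shown here, no step from compound 1 to compound 3 can be read, because every value stands at the same limit: the limit of > 60000 nM in this assay, at which 3 of the 3 values shown sit. The compounds shown leave open whether 4-methylpiperidin-1-yl and phenyl(propyl)amino differ at all in their effect on inhibition.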